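A few compounds are considered here, and "the series" means these few. Any claim that something is new, unique, unknown or untested is made for them only; others in the source may bear on it.

For the measured compounds named here, in an ADME assay on J774.A1 cells (Mus musculus) for cytotoxicity, read by MTT assay, with a stated time of 48 h (a higher number here means that more compound is tolerated, a lower number that less compound is tolerated), compound 1 `O=C(NCc1cccc(Cl)c1Cl)c1c([N+](=O)[O-])noc1-c1ccc(Cl)cc1` gives 73700 nM and compound 2 `O=C(NCc1ccc(F)cc1)c1c([N+](=O)[O-])noc1-c1ccc(Cl)cc1Cl` gives 86400 nM on the same read-out, so compound 2 stands within the scatter of compound 1, the only other number available. These two compounds differ in more than one place, and no single change can be read from their values.

The next compound is compound 3 `O=C(NCc1cccc(Cl)c1Cl)c1c([N+](=O)[O-])noc1-c1ccc(Cl)cc1Cl`, which departs from compound 2 in one place only, as 2,3-dichlorophenyl in place of 4-fluorophenyl on a saturated chain carbon bound to an amide-type nitrogen shows: 2,3-dichlorophenyl in place of 4-fluorophenyl on a saturated chain carbon bound to an amide-type nitrogen. Going by the values given here, the entering group already stands in compound 1, whose value of 73700 nM is the only evidence for it, and no measured pair isolates this change. On that basis no step beyond the scatter is expected in this assay in either direction. The estimated step of a 1.2-fold lower number from compound 2 to compound 3 (0.06 log units; within the scatter) stays within the scatter. For compound 3 the estimated value is 75000 nM with an expected range from 40000 nM to 130000 nM on this evidence.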

Compound 3, half-maximal cytotoxic concentration: 81800 nM
The estimate for compound 3 lay 1.1-fold (0.04 log units) below the measured number; measured number inside the range.
By their numbers in this assay, from the lowest: compounds 1, 3 and 2 (each within the scatter of the next).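

In this assay the exchange of 2,3-dichlorophenyl for 4-fluorophenyl on a saturated chain carbon bound to an amide-type nitrogen is now isolated in a measured pair, which gives a 1.1-fold lower number from compound 2 to compound 3 (0.02 log units; within the scatter) and so leaves the two compounds indistinguishable on this read-out. For the compounds shown here, the second pair gives the first reading of chloro in place of hydrogen on an aromatic carbon, namely a 1.1-fold higher number from compound 1 to compound 3 (0.05 log units; within the scatter), and this change too leaves the two compounds indistinguishable. Nothing measured here explains why neither change separates its pair.

From the compounds shown here alone, all three compounds carry only halogen-substituted phenyl groups on the shared core, so the effect of an amine or a carboxylic acid at the position on the saturated chain carbon, or of a longer chain there, remains open in this assay for this series. Going by these compounds, each change also rests on a single pair, so it remains open whether either one reads the same when the rest of the molecule differs.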